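A Longer Chain on Compound 2

The source may hold more compounds than are shown below. What is called first, only, known or untested is meant among the compounds shown, and "the series" means these compounds.

Among the measured compounds shown here, in a physicochemical assay for lipophilicity (a higher number here means a more lipophilic compound, a lower number a more polar compound), compound 2 `CCCCS(=O)(=O)c1ccc(O)c(C(=O)Nc2ccc(C(F)(F)F)cc2)c1` stands at 3.1, the higher of the two numbers measured so far. Compound 1 `CCCCS(=O)(=O)c1ccc(O)c(C(=O)Nc2ccc(Br)cc2)c1` gives 2.48. For the measured compounds named here, the only measured step, a number 0.62 log units higher from compound 1 to compound 2 (beyond the scatter), is modest but beyond the scatter, and it comes from trifluoromethyl in place of bromo on an aromatic carbon.

Compound 3 `CCCCCCCCS(=O)(=O)c1ccc(O)c(C(=O)Nc2ccc(C(F)(F)F)cc2)c1` differs from compound 2 by butyl in place of hydrogen on a saturated chain carbon, four bonds along the chain from a sulfonyl sulfur. Going by the values given here, no measured step involves a change on the chain, so the step to compound 3 has no direct precedent and only a rough scale to go on. With a butyl entering, a clear rise is expected, larger than the modest step measured so far and beyond the scatter. The estimate is a number 1.60 log units higher from compound 2 to compound 3 (beyond the scatter), towards a higher number. Compound 3 is expected at 4.7, with an estimated range of 3.9 to 5.5.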

Compound 3, distribution coefficient: 5.26
The estimate for compound 3 lay 0.56 log units below the measured number, within the range that was stated.
By their numbers in this assay, from the lowest: compound 1; then compound 2; then compound 3.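

Among the compounds shown here, compound 3 gives the first measured change on the chain, and in this assay butyl in place of hydrogen at this carbon, four bonds along the chain from a sulfonyl sulfur, gives a number 2.16 log units higher from compound 2 to compound 3 (beyond the scatter), a large step beyond the scatter. This is larger than the modest step on the aromatic carbon, a number 0.62 log units higher from compound 1 to compound 2 (beyond the scatter), so among these compounds the chain position carries the bigger change in the number. Nothing measured here accounts for the size of this step.

A single step on the chain leaves open how the number moves with a smaller addition such as ethyl, with a longer chain, or with a carboxylic acid or an amine at the same carbon. It also leaves open whether butyl would give a similar step with bromo on the aromatic carbon, as in compound 1.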